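Methoxy removal in pyrazine ester cinnamic acids: cytotoxicity notes

The source may hold more compounds than are shown below. What is called first, only, known or untested is meant among the compounds shown, and "the series" means these compounds.

Measured compounds:
compound 1 `COc1cc(/C=C/C(=O)O)ccc1OC(=O)c1nc(C)c(C)nc1C` – 40.3%
compound 2 `COc1ccc(/C=C/C(=O)O)cc1OC(=O)c1nc(C)c(C)nc1C` – 128%
compound 3 `Cc1nc(C)c(C(=O)Oc2ccc(/C=C/C(=O)O)cc2)nc1C` – 46.6%

All three were run in a functional assay on EA.hy 926 cells (Homo sapiens) for cytotoxicity, read by MTT assay, with stated times of 24 h and 12 h, tested at 25 uM; on this read-out lower numbers stand for a weaker effect and higher numbers for a stronger effect at the one concentration tested. Compound 1 and compound 2 are built from the same atoms joined differently; the difference between the two cores is not broken down here. In this assay compound 2 gives 128%, and both other compounds lie far lower.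

Compound 3 differs from compound 1 by one change, (hydrogen in place of methoxy on an aromatic carbon), and the step is a number 6.3 percentage points higher from compound 1 to compound 3 (within the scatter), so loss of the methoxy from compound 1 leaves the read-out essentially where it was.

The unmeasured compound 4 `Cc1nc(C)c(C(=O)Oc2cccc(/C=C/C(=O)O)c2)nc1C` stands to compound 2 as compound 3 stands to compound 1: hydrogen in place of methoxy on an aromatic carbon. The change is the same kind, but the surroundings differ: in compound 1 the leaving methoxy is meta to a 2-carboxyethenyl group, in compound 2 it is para to a 2-carboxyethenyl group.

For the measured compounds named here, the only guide for the expected step from compound 2 to compound 4 is the earlier step, which was within the scatter; on that basis a step of a number 23 percentage points lower from compound 2 to compound 4 (beyond the scatter) is estimated, with wide uncertainty, because the starting point of compound 2 is 128% and the two earlier places are not identical. Compound 4 is thus expected to give about 105% in this assay, between 65% and 135%.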

Compound 4, a percentage reported as activity, at one concentration (the size of the read-out at that concentration, not a potency): 64.3%
Beside the measured number, compound 4's estimate is 40.7 percentage points above it; the measured number lies below the stated range.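

In this assay, hydrogen in place of methoxy on the core of compound 2 is a large change, read as a number 63.7 percentage points lower from compound 2 to compound 4 (beyond the scatter). The size of this step therefore does not carry over from one core to the other, and the result on the core of compound 1 gives no safe guide to the result on the core of compound 2: the same change on two cores in this assay, a number 6.3 percentage points higher (within the scatter) from compound 1 to compound 3 and a number 63.7 percentage points lower (beyond the scatter) from compound 2 to compound 4, 70 percentage points apart, beyond the scatter of two such steps. These two pairs show only that the outcome of this one change depends on the core in this series; they do not show which difference between the cores is responsible or what the change would do on any further core, and a read-out at one concentration gives no potency.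

Going by these compounds, it remains open whether the large step on the core of compound 2 is specific to methoxy or would also appear with a hydroxyl, an ethoxy or a fluorine at the same place. Also open, on these data alone, is whether the gap between the two pairs would persist with an amide in place of the ester link or with a saturated propanoic acid chain in place of the 2-carboxyethenyl group.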